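Swapping the Side Chain: Expected Efficacy of Compound 4

The compounds below may be only part of what the source reports. "The series", "measured", "known", "first", "only" and "open" are said of these compounds alone.

Three compounds have so far been measured in a functional assay on CHO cells for activation of 5-hydroxytryptamine receptor 1D (Homo sapiens), read by GTPgammaS binding; a higher number here means a larger maximal response, a lower number a smaller maximal response:

Compound 1, `COC[C@H](NC1CCN(CCCc2c[nH]c3ccc(-n4cnnc4)cc23)CC1)c1ccccc1`, gives 93%.
Compound 2, `c1ccc(C2CCCCN2C2CCN(CCCc3c[nH]c4ccc(-n5cnnc5)cc34)CC2)cc1`, gives 65%.
Compound 3, `NC(=O)OC[C@H](NC1CCN(CCCc2c[nH]c3ccc(-n4cnnc4)cc23)CC1)c1ccccc1`, gives 73%.

Compound 1 gives the highest of these three numbers. Its nearest neighbour is compound 3, reached by a single change, a number 20 percentage points lower from compound 1 to compound 3 (beyond the scatter), a modest fall that lies beyond the usual scatter. For the measured compounds named here, compound 2 sits further below compound 1, and between those two no single-point step is defined, so only their two values can be compared.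

Compound 4, `c1ccc(CNCC2CCN(CCCc3c[nH]c4ccc(-n5cnnc5)cc34)CC2)cc1`, differs from compound 1 in one place: (benzylamino)methyl in place of (2-methoxy-1-phenylethyl)amino on a saturated ring carbon. Going by the values given here, the only measured step that touches the same region is the one from compound 1 to compound 3, where a small change on the side chain cost a modest amount of maximal response. Among the compounds with values here, the change to compound 4 is larger, since the whole side chain on that ring carbon is exchanged, and no measured pair mirrors it. With both neighbours of compound 1 lying lower, a fall in this assay is the more likely direction, of roughly the size seen for compound 3, though a result within the scatter cannot be excluded. The expected step is a number 20 percentage points lower from compound 1 to compound 4 (beyond the scatter). Compound 4 is therefore estimated at 73%, between 52% and 94%.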

Compound 4, largest response reached (reported as efficacy), in percent of the reference or control that the assay uses: 101%
Beside the measured number, compound 4's estimate is 28 percentage points below it, and the stated range ends below it.
By their numbers in this assay, from the lowest: compounds 2 and 3 (each within the scatter of the next); then compounds 1 and 4 (each within the scatter of the next).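

In this assay, exchanging (2-methoxy-1-phenylethyl)amino for (benzylamino)methyl on the saturated ring carbon gives a number 8 percentage points higher from compound 1 to compound 4 (within the scatter), so the two compounds cannot be told apart by maximal response. This shows that this position tolerates a complete exchange of its side chain, at least for this pair: the oxygen and the defined stereocentre of compound 1 are both absent from compound 4, and the high response remains. It also shows that the size of an edit need not match the size of its outcome, since the smaller edit on the same side chain gave a number 20 percentage points lower from compound 1 to compound 3 (beyond the scatter), whereas this larger exchange stays within the scatter, and no data shown here explain the contrast.

As far as these compounds go, the exchange alters several features at once, so it remains open whether the oxygen, the stereocentre or the placement of the nitrogen matters on its own. From the compounds shown here alone, it is also open how the response would respond to a carboxylic acid on this side chain or to a longer chain leading to the phenyl ring.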